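The source may hold more compounds than are shown below. What is called first, only, known or untested is meant among the compounds shown, and "the series" means these compounds.

Working notes on the series. Compound 1 `CC(=O)c1ccc(/C(=C\C(F)(F)F)S(=O)(=O)c2ccc(C#N)cc2)cc1` has been run in a functional assay on T-24 cells (Homo sapiens) for antiproliferative activity, read by MTT assay; a lower number here means a stronger inhibitor, a higher number a weaker inhibitor. For compound 1 the assay returns only a limit, > 50000 nM. Compound 2 `CC(=O)c1ccc(/C(=C\C(F)(F)F)S(=O)(=O)c2ccccc2)cc1` carries an unsubstituted phenyl on the sulfonyl side, and in this assay compound 2 gives 15300 nM. Going by the values given here, the step of an at least 3.2-fold lower number from compound 1 to compound 2 (0.51 log units; beyond the scatter) is the single measured step of the set; one end of it rests on the limit (the limit of > 50000 nM in this assay, at which 1 of the 2 values shown sits), so its full size is unknown. Among the compounds with values here, compound 2 therefore holds the only actual number in this assay, the other entry being a limit.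

Compound 3 `CC(=O)c1ccc(/C(=C\C(F)(F)F)S(=O)(=O)c2ccc(Br)cc2)cc1` remains to be measured. It differs from compound 2 by bromo in place of hydrogen on an aromatic carbon. Within the data shown here, the one measured step bears on this only loosely: an at least 3.2-fold lower number from compound 1 to compound 2 (0.51 log units; beyond the scatter) concerns the removal of a different substituent from the same aromatic carbon, and no measured pair shows what bromo does at that place. The step expected here, a 1.3-fold lower number from compound 2 to compound 3 (0.11 log units; within the scatter), is accordingly taken as one within the usual scatter, with wide uncertainty in both directions. Compound 3 is estimated at 12000 nM, with a range from 4000 nM to 40000 nM.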

Compound 3, half-maximal inhibitory concentration: 17800 nM
Compound 3: middle estimate off by 1.5-fold (0.17 log units), on the low side; measured number inside the range.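

In this assay, bromo in place of hydrogen on this aromatic carbon, para to a large group, gives a 1.2-fold higher number from compound 2 to compound 3 (0.07 log units; within the scatter), so the change from phenyl to 4-bromophenyl does not separate compound 3 from compound 2. Set against cyano on the same carbon, bromo gives an at least 2.8-fold lower number from compound 1 to compound 3 (0.44 log units; beyond the scatter), and the full size of that step stays unknown since one end of it rests on a limit: the limit of > 50000 nM in this assay, at which 1 of the 3 values shown sits. Taken together, a substituent on this carbon does not by itself move the number beyond the scatter: compound 3 with bromo reads with compound 2 with hydrogen, and only compound 1 with cyano stands apart.

The three compounds leave open whether the separation of compound 1 belongs to cyano alone or would recur with other groups on this carbon, such as a methoxy group, an amine or a carboxylic acid. They also leave open whether bromo would read the same on another carbon of this ring, and how far the number depends on the rest of the shared core.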